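The compounds below may be only part of what the source reports. "The series", "measured", "known", "first", "only" and "open" are said of these compounds alone.

Among the measured compounds shown here, compound 2 `c1ccc(-c2cc[nH]n2)c(OCC2=NCCN2)c1` holds the higher of the two numbers measured so far in a functional assay with Alpha-1A adrenergic receptor (Homo sapiens) as the target, read by calcium flux; a higher number here means a larger maximal response, a lower number a smaller maximal response: compound 2 reaches 119%, while compound 1 `c1ccc(-c2ccsc2)c(OCC2=NCCN2)c1` reaches 98%. For the measured compounds named here, the single step between them, a number 21 percentage points higher from compound 1 to compound 2 (beyond the scatter), came with the exchange of thiophen-3-yl for 1H-pyrazol-3-yl on an aromatic carbon. Compound 3 `Cc1cnsc1-c1ccccc1OCC1=NCCN1` has not yet been measured. It differs from compound 2 in one place: 4-methyl-1,2-thiazol-5-yl in place of 1H-pyrazol-3-yl on an aromatic carbon. Going by the values given here, the group that enters brings a sulfur atom back into the five-membered ring and removes the one hydrogen-bond donor that compound 2 carries, so in those counted features compound 3 stands closer to compound 1 than compound 2 does. Among the compounds with values here, the only measured step that bears on this change is a number 21 percentage points higher from compound 1 to compound 2 (beyond the scatter), which lifted the maximal response beyond the scatter when the donor-bearing ring came in. Taking that ring away again is therefore expected to move the number back in the other direction, by a step of about a number 19 percentage points lower from compound 2 to compound 3 (beyond the scatter) in this assay. Compound 3 is estimated at 100%, with a range from 80% to 122%.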

Compound 3, largest response reached (reported as maximum), in percent of the reference or control that the assay uses: 104%
For compound 3 the middle estimate is 4 percentage points below the measured one; measured number inside the range.
By their numbers in this assay, from the lowest: compounds 1 and 3 (each within the scatter of the next); then compound 2.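

At this position, on an aromatic carbon of a six-membered aromatic ring of carbon only, this assay shows a number 15 percentage points lower from compound 2 to compound 3 (beyond the scatter) when 4-methyl-1,2-thiazol-5-yl replaces 1H-pyrazol-3-yl, so the response seen with that ring does not carry over to this second ring with two hetero atoms. Set against thiophen-3-yl, the same group gives a number 6 percentage points higher from compound 1 to compound 3 (within the scatter) and so leaves the two sulfur-bearing rings indistinguishable in this read-out, even though 4-methyl-1,2-thiazol-5-yl also brings a ring nitrogen and a methyl group. Of the three compounds, only compound 2 stands apart and only compound 2 carries a hydrogen-bond donor in this ring, but that match rests on three compounds and no separate measurement explains it.

The change from 1H-pyrazol-3-yl to 4-methyl-1,2-thiazol-5-yl alters the donor, the sulfur and the methyl group together, so their shares in the step remain unresolved. A 1-methyl-1H-pyrazol-3-yl ring or an unsubstituted 1,2-thiazol-5-yl ring would separate these parts, while a plain phenyl ring or a ring carrying an amine would show how far the response at this position can range.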